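Swapping chloro for 1-hydroxyethyl: expected antiproliferative shift

The compounds below may be only part of what the source reports. "The series", "measured", "known", "first", "only" and "open" are said of these compounds alone.

Compound 1, `CC(Nc1ccccc1Oc1ccc(Cl)cc1)=C1C(=O)CC(c2ccccc2)CC1=O`, gives 250 nM in a functional assay on L1210 cells (Mus musculus) for antiproliferative activity, read by cell counting, with a stated time of 96 h; on this read-out higher numbers stand for weaker inhibition and lower numbers for stronger inhibition.
Compound 2, `CC(Nc1ccccc1Oc1ccccc1)=C1C(=O)CC(c2ccccc2)CC1=O`, gives 86 nM.
Compound 3, `COc1cc(Oc2ccccc2NC(C)=C2C(=O)CC(c3ccccc3)CC2=O)ccc1N`, gives 26 nM.

Compound 1 thus stands highest of the three, the weakest inhibitor among them. Compound 4, `CC(Nc1ccccc1Oc1ccc(C(C)O)cc1)=C1C(=O)CC(c2ccccc2)CC1=O`, differs from it in one place: 1-hydroxyethyl in place of chloro on an aromatic carbon. Among the compounds with values here, two measured steps bear on this. Removing the chloro gave a 2.9-fold lower number from compound 1 to compound 2 (0.46 log units; beyond the scatter), and replacing 4-chlorophenyl with 4-amino-3-methoxyphenyl gave a 9.6-fold lower number from compound 1 to compound 3 (0.98 log units; beyond the scatter); between those two compounds the step was a 3.3-fold lower number from compound 2 to compound 3 (0.52 log units; beyond the scatter). Both changes away from chloro lowered the number, so a modest lowering is expected here too, although 1-hydroxyethyl matches neither of those groups. Compound 4 is therefore estimated at 70 nM, with a range from 25 nM to 200 nM, a step of a 3.6-fold lower number from compound 1 to compound 4 (0.55 log units; beyond the scatter).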

Compound 4, half-maximal inhibitory concentration: 58 nM
Estimate against measurement, compound 4: 1.2-fold (0.08 log units) above; the measured number falls inside the stated range.
By their numbers in this assay, from the lowest: compound 3; then compounds 4 and 2 (each within the scatter of the next); then compound 1.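

Replacing the chloro with 1-hydroxyethyl also lowers the number (from a 4.3-fold lower number from compound 1 to compound 4 (0.63 log units; beyond the scatter)), so this position takes a larger group carrying a hydrogen-bond donor and acceptor. Yet this group cannot be told apart from plain hydrogen (from a 1.5-fold lower number from compound 2 to compound 4 (0.17 log units; within the scatter)), so the gain may come simply from losing the chloro, while 4-amino-3-methoxyphenyl remains the better group (from a 2.2-fold higher number from compound 3 to compound 4 (0.35 log units; beyond the scatter)). Nothing measured here offers a reason for these shifts.

Open, as far as these compounds go, is what the hydroxyl itself contributes, which an ethyl group in the same place would test. Also open, from the compounds shown here alone, is whether a carboxylic acid there would hold this level.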